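The source may report more compounds than this note shows. Statements on the series, on what has been measured and on what is new or still open speak of the compounds shown alone.

In a functional assay on MCF7 cells (Homo sapiens) for cytotoxicity, read by MTT assay, with a stated time of 72 h (a higher number here means a weaker inhibitor, a lower number a stronger inhibitor), compound 3 `O=C(CCc1ccc(NC(=O)Nc2ccc(Cl)cc2)cc1)NO` gives > 50000 nM as a limit of the assay and not a number. Its position is therefore known only as a limit. Compound 1 `COc1ccc(NC(=O)Nc2ccc(C(=O)NO)cc2)cc1` gives > 50000 nM and this too is a limit. Compound 2 `COc1ccc(NC(=O)Nc2ccc(/C=C/C(=O)NO)cc2)cc1` gives > 50000 nM as a limit as well.

The change under study leads to compound 4 `COc1ccc(NC(=O)Nc2ccc(CCC(=O)NO)cc2)cc1` and touches one place only: methoxy in place of chloro on an aromatic carbon with methoxy in place of chloro on an aromatic carbon, para to a large group.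

Within the data shown here, the one measured step is a step that the two limits leave unreadable from compound 1 to compound 2 and it concerns a different place, so it offers no size to carry over. The wider picture is the limit of > 50000 nM in this assay, at which 3 of the 3 values shown sit, and this covers the chloro compound 3 and both methoxy compounds 1 and 2.

With the same methoxy group, compound 2 stays on its limit of > 50000 nM and so no step beyond the scatter is expected in this assay and no direction can be named. The expected change is a step that the limit leaves unreadable from compound 3 to compound 4 on the estimate that follows. The estimate for compound 4 is 60000 nM within an expected range of 25000 nM to 100000 nM and a report as a limit once more is the likeliest outcome.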

Compound 4, half-maximal inhibitory concentration: > 50000 nM
Compound 4 gave a limit, no number; the forecaster's own chance of this, stated with the estimate: 85%; the middle value is on the limit's open side.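

In this assay compound 4 gives > 50000 nM, a limit of the assay and not a number. Its steps from compound 1, compound 2 and compound 3 therefore cannot be read, and the series offers only one shared limit: the limit of > 50000 nM in this assay, at which 4 of the 4 values shown sit.

The compounds shown leave open how far any of them lies beyond that limit, and whether methoxy in place of chloro has any measurable size in this assay.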